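Compound 3: a phenyl swap on the shared core

A few compounds are considered here, and "the series" means these few. Any claim that something is new, unique, unknown or untested is made for them only; others in the source may bear on it.

Measured so far in a physicochemical assay (a higher number here means a weaker inhibitor, a lower number a stronger inhibitor), for two compounds
Compound 1 `O=c1[nH]nc(Cc2ccccc2)n1/N=C/c1ccc(O)c(O)c1` gives 0.026 ug/mL
Compound 2 `Cc1n[nH]c(=O)n1/N=C/c1ccc(O)c(O)c1` gives 0.025 ug/mL

Compound 2 at 0.025 ug/mL stands level with compound 1 within the scatter, and these two numbers are all the data in hand. Compound 3 `O=c1[nH]nc(-c2ccccc2)n1/N=C/c1ccc(O)c(O)c1` differs from compound 2 by one change (phenyl in place of methyl on an aromatic carbon), phenyl in place of methyl on an aromatic carbon.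

Within the data shown here, one measured step bears on this (a 1.0-fold lower number from compound 1 to compound 2 (0.02 log units; within the scatter)), hydrogen in place of phenyl on a saturated chain carbon bound to an aromatic carbon. It stayed within the scatter, but it is only a partial guide. Among the measured compounds shown here, there the phenyl sits on a saturated chain carbon, whereas in compound 3 it stands on the aromatic carbon itself, and no such compound has been measured. No step beyond the scatter is therefore expected in this assay in either direction, though the range is kept wide. The expected change is small (a 1.2-fold higher number from compound 2 to compound 3 (0.08 log units; within the scatter)) and lies within the scatter. Compound 3 is expected at 0.03 ug/mL with an estimated range of 0.012 ug/mL to 0.07 ug/mL for the coming measurement.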

Compound 3, half-maximal inhibitory concentration: 0.5 ug/mL
The estimate for compound 3 lay 17-fold (1.22 log units) below the measured number, and the stated range ends below it.
By their numbers in this assay, from the lowest: compounds 2 and 1 (each within the scatter of the next); then compound 3.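

In this assay, the aromatic carbon of the five-membered aromatic ring now proves sensitive to its substituent, which the earlier pair could not show: replacing methyl with phenyl gives a 20-fold higher number from compound 2 to compound 3 (1.30 log units; beyond the scatter) on this carbon, whereas the earlier step, made on a saturated chain carbon, stayed within the scatter. Replacing benzyl with phenyl gives a 19-fold higher number from compound 1 to compound 3 (1.28 log units; beyond the scatter) and points the same way, so in these compounds a phenyl group is compatible with a low number when it is carried as benzyl, but not when it stands on the aromatic carbon itself. No measurement in hand accounts for either step.

The compounds shown do not separate an effect of phenyl in particular from one shared by other aromatic rings on this carbon, and a pyridyl or thienyl group, or a phenyl bearing a fluorine or methoxy substituent, would bear on that. Going by these compounds, how far the tolerance for methyl and benzyl extends also remains open, including for an ethyl or longer chain, a phenethyl group, an amine or a carboxylic acid at this place.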